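From Compound 2 to Compound 4 at the Ring Amine

This account rests on a few compounds, and the source may have more. Where it says the series, first, only, none or still open, it means among the compounds named here.

Of the compounds shown here, three sharing one core have been measured in an assay on CHO cells for displacement of a labelled ligand from adenosine receptor A1 (Homo sapiens), read by scintillation counting, with a stated time of 90 min, tested at 1 uM, in the presence of a further agent that is not named here; on this read-out higher numbers stand for more inhibition at the one concentration tested (going by the name of the read-out) and lower numbers for less inhibition. Compound 2 `CCCn1c(=O)[nH]c2nc(-c3ccc(S(=O)(=O)N4CCN(c5ccccc5Br)CC4)cc3)[nH]c2c1=O` gives 28%, the highest of the three numbers. Compound 1 `CCCn1c(=O)c2[nH]c(-c3ccc(S(=O)(=O)N4CCN(c5ccc(Cl)cc5)CC4)cc3)nc2n(CC)c1=O` gives 24%, a number within the scatter of compound 2, so no order between these two can be read. Compound 3 `CCCn1c(=O)[nH]c2nc(-c3ccc(S(=O)(=O)N4CCN(c5ccccc5)C(C)C4)cc3)[nH]c2c1=O` gives 15%, which lies beyond the scatter below compound 2. No pair among these three differs in only one place, so no single-change step is available from them.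

Compound 4 `CCCn1c(=O)[nH]c2nc(-c3ccc(S(=O)(=O)N4CCN(c5ccc(F)cc5)CC4)cc3)[nH]c2c1=O` has not yet been measured. It differs from compound 2 in one place: 4-fluorophenyl in place of 2-bromophenyl on an amine nitrogen in a ring. Among the measured compounds shown here, with no measured step of this kind to lean on, the expected change in this assay is small, at most a modest move downward, and most likely none beyond the scatter. Compound 4 is therefore estimated at 22%, with a range from 8% to 38%. That estimate means an expected step of a number 6 percentage points lower from compound 2 to compound 4 (within the scatter), which stays within the usual scatter.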

Compound 4, a percentage reported as inhibition, at one concentration (the size of the read-out at that concentration, not a potency): 14%
Estimate against measurement, compound 4: 8 percentage points above; the measured number falls inside the stated range.
By their numbers in this assay, from the lowest: compounds 4, 3, 1 and 2 (each within the scatter of the next, the first and the last beyond it).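

In this assay, among the compounds shown here, the only single-change step falls on the aryl group on the amine nitrogen in the ring: 4-fluorophenyl in place of 2-bromophenyl gives a number 14 percentage points lower from compound 2 to compound 4 (beyond the scatter), so the number responds to a change at this position. Both groups are phenyl rings bearing one halogen, with the same counts of heavy atoms, hydrogen-bond donors and hydrogen-bond acceptors and no net charge, yet the step joins two changes, the halogen and its place on the phenyl ring, and this one pair cannot separate them. Nothing available here accounts for the step.

From the compounds shown here alone, it remains open whether a 2-fluorophenyl or a 4-bromophenyl group would read nearer compound 2 or compound 4, which would separate the halogen from its place. Also open, going by these compounds, is how an unsubstituted phenyl, a cyclohexyl ring or a phenyl ring bearing a carboxylic acid would read on this nitrogen.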